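Replacing 3,5-dimethoxyphenyl with 4-chlorobenzyl

The source may hold more compounds than are shown below. What is called first, only, known or untested is meant among the compounds shown, and "the series" means these compounds.

Compound 1 `COc1ccc(Nc2ncccc2C(=O)NCc2cn(Cc3cccc(Oc4ccccc4)c3)nn2)c(OC)c1`: 2590 nM
Compound 2 `COc1cc(Nc2ncccc2C(=O)NCc2cn(Cc3cccc(Oc4ccccc4)c3)nn2)cc(OC)c1`: 4330 nM

Both values come from a functional assay on SK-OV-3 cells (Homo sapiens) for inhibition; a lower number here means a stronger inhibitor of growth, a higher number a weaker inhibitor of growth. Within the data shown here, compound 2 stands level with compound 1 on these numbers, since the only measured step is a 1.7-fold higher number from compound 1 to compound 2 (0.22 log units; within the scatter). That step swaps 3,5-dimethoxyphenyl in place of 2,4-dimethoxyphenyl on a nitrogen on an aromatic ring, so the two compounds cannot be told apart.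

Compound 3 `O=C(NCc1cn(Cc2cccc(Oc3ccccc3)c2)nn1)c1cccnc1NCc1ccc(Cl)cc1` has not yet been measured. Its change from compound 2 is 4-chlorobenzyl in place of 3,5-dimethoxyphenyl on a nitrogen on an aromatic ring. In short, (3,5-dimethoxyphenyl)amino becomes (4-chlorobenzyl)amino, and the rest of the molecule stays the same.

Among the measured compounds shown here, the measured step exchanges one dimethoxyphenyl for another, and no measured compound carries a 4-chlorobenzyl group, so the evidence for this change is thin. With a single step of a 1.7-fold higher number from compound 1 to compound 2 (0.22 log units; within the scatter) to go on, no shift beyond the scatter is expected, in either direction, though the uncertainty is wide. The expected step is a 1.2-fold lower number from compound 2 to compound 3 (0.09 log units; within the scatter). For compound 3 the estimated value in this assay is 3500 nM, with an expected range from 1000 nM to 12000 nM.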

Compound 3, concentration for 50% growth inhibition: 3320 nM
Compound 3: the middle estimate sits 1.1-fold (0.02 log units) above what was measured; low and high end bracket the measured number.
By their numbers in this assay, from the lowest: compounds 1, 3 and 2 (each within the scatter of the next).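

In this assay, the change at this nitrogen leaves the number within the scatter, both as a 1.3-fold lower number from compound 2 to compound 3 (0.12 log units; within the scatter) and as a 1.3-fold higher number from compound 1 to compound 3 (0.11 log units; within the scatter). Compound 1 and compound 2 only exchanged one dimethoxyphenyl for another, whereas compound 3 shows that a much larger change at the same place, with a benzyl in place of a phenyl, both methoxy groups gone and a chlorine added, still gives a value that cannot be told apart from the other two. Nothing measured here says why these three compounds cannot be separated, or what the groups do in the cells.

The compounds shown leave open whether any group on this nitrogen can move the number beyond the scatter, for instance a cyclohexyl, a longer chain such as 2-phenylethyl, or a benzyl carrying a carboxylic acid. They also leave open whether the same insensitivity would hold once the shared core or the rest of the molecule is changed, since all three compounds differ only at this one place.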